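The source may hold more compounds than are shown below. What is called first, only, known or untested is meant among the compounds shown, and "the series" means these compounds.

Measured so far:
compound 1, `CC(C(=O)N1CCN(c2ccc(F)cc2)CC1)N1C(=O)CCC1=O`, 0%
compound 2, `Cc1cccc(N2CCN(C(=O)C(C)N3C(=O)CCC3=O)CC2)c1`, 0%

For the measured compounds named here, in a functional assay on the whole organism (strain Swiss) with Mus musculus as the target, in the maximal electroshock model, with a stated time of 0.5 h, at a dose of 100 mg/kg by the intraperitoneal route (a lower number here means a weaker effect, a higher number a stronger effect of the compound at the dose given), compound 2 gives 0%, level with compound 1 at the digits printed; the one step among the measured pair, no change at the digits printed from compound 1 to compound 2 (within the scatter), lies within the scatter, so nothing in this pair separates them. Compound 3 is `CC(C(=O)N1CCN(c2ccccc2)CC1)N1C(=O)CCC1=O`. It differs from compound 2 by hydrogen in place of methyl on an aromatic carbon; cut one bond further out, the same difference reads 3-methylphenyl to phenyl. Going by the values given here, the only step that bears on it is the swap of groups on the same amine nitrogen, no change at the digits printed from compound 1 to compound 2 (within the scatter), which gave no change, and both measured compounds sit at the bottom of the scale, so no step beyond the scatter is expected in this assay. Compound 3 is therefore expected to give 0%, with a range from 0% to 10%. For compound 3 the expected step is no change at the digits printed from compound 2 to compound 3 (within the scatter).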

Compound 3, a percentage reported as activity, at one dose (the size of the read-out at that dose, not a potency): 0%
For compound 3 middle estimate and measured number coincide at the digits printed, and the stated range covers the measured number.
By their numbers in this assay, from the lowest: compounds 1, 2 and 3 (each within the scatter of the next).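

Hydrogen now stands where the earlier compounds carried a group on this aromatic ring, and in this assay neither loss shows up: hydrogen in place of methyl gives (no change at the digits printed from compound 2 to compound 3 (within the scatter)) and hydrogen in place of fluoro gives (no change at the digits printed from compound 1 to compound 3 (within the scatter)). The plain phenyl compound therefore cannot be told apart from the 3-methylphenyl and 4-fluorophenyl compounds at this dose, and with all three at the bottom of the scale, the read-out cannot show whether either group matters at all. No measurement shown here accounts for this outcome.

Open, on these data alone, is whether another group on this ring, such as methoxy or trifluoromethyl, would lift the read-out off the bottom of the scale. Also open, as far as these compounds go, is whether a longer chain in place of the methyl on the shared core would do so.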